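Furan to Pyridine on the Shared Core: Clearance Expectation

The compounds below may be only part of what the source reports. "The series", "measured", "known", "first", "only" and "open" are said of these compounds alone.

Measured compounds:
Compound 1 `Nc1ccc(S(=O)(=O)N2CCN(c3ncc(C(O)(C(F)(F)F)C(F)(F)F)cc3C#CC3CC3)CC2)cn1`: 67 mL.min-1.g-1
Compound 2 `Nc1ccc(S(=O)(=O)N2CCN(c3ncc(C(O)(C(F)(F)F)C(F)(F)F)cc3-c3ccoc3)CC2)cn1`: 57 mL.min-1.g-1

Of the compounds shown here, two have so far been measured in an ADME assay (liver) for metabolic stability, with Liver microsome (Rattus norvegicus) as the target, using microsomes and NADPH, with a stated time of 30 min, tested at 1 uM; a higher number here means faster removal of the compound, a lower number slower removal. Compound 2 stands at the lowest of the two numbers, and its nearest neighbour is compound 1, separated from it by a 1.2-fold lower number from compound 1 to compound 2 (0.07 log units; within the scatter). That step lies within the scatter, so no order between the two compounds can be claimed. It exchanged furan-3-yl for 2-cyclopropylethynyl on an aromatic carbon.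

Compound 3 `Nc1ccc(S(=O)(=O)N2CCN(c3ncc(C(O)(C(F)(F)F)C(F)(F)F)cc3-c3ccncc3)CC2)cn1` has not yet been measured. It differs from compound 2 by pyridin-4-yl in place of furan-3-yl on an aromatic carbon. Within the data shown here, no measured step involves pyridin-4-yl, and the only step available, a 1.2-fold lower number from compound 1 to compound 2 (0.07 log units; within the scatter), concerns a different group at the same aromatic carbon and was itself within the scatter. There is therefore no basis in the measured numbers for expecting a change in this assay beyond the scatter in either direction. The step that this estimate means is expected to be a 1.1-fold lower number from compound 2 to compound 3 (0.06 log units; within the scatter). Compound 3 is estimated at 50 mL.min-1.g-1, with a range from 22 mL.min-1.g-1 to 110 mL.min-1.g-1.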

Compound 3, intrinsic clearance in microsomes: 31 mL.min-1.g-1
The estimate for compound 3 lay 1.6-fold (0.21 log units) above the measured number, and the stated range covers the measured number.
By their numbers in this assay, from the lowest: compounds 3, 2 and 1 (each within the scatter of the next, the first and the last beyond it).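

In this assay, the aromatic carbon ortho to a large group and two atoms from the ring nitrogen now gives its first step beyond the scatter (a 2.2-fold lower number from compound 1 to compound 3 (0.33 log units; beyond the scatter)), although that step is modest. The position therefore responds at least somewhat to the group it carries, which the earlier pair could not show, with pyridin-4-yl and 2-cyclopropylethynyl separated in this read-out while furan-3-yl remains unresolved from both. The direct exchange of furan-3-yl for pyridin-4-yl (a 1.8-fold lower number from compound 2 to compound 3 (0.26 log units; within the scatter)) stays within the scatter, so compound 2 and compound 3 cannot be ordered, and nothing available accounts for the separation between compound 1 and compound 3.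

The compounds shown leave open whether the ring nitrogen of pyridin-4-yl matters to this read-out, a question that a phenyl ring or a pyridin-3-yl group at the same carbon would address. They also leave open whether a saturated group at this carbon, such as a morpholine or an aliphatic amine, would fall with these aromatic and alkyne groups or apart from them.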